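Methoxy addition on two related enone-lactone cores

The compounds below may be only part of what the source reports. "The series", "measured", "known", "first", "only" and "open" are said of these compounds alone.

Compound 1 `COc1ccc(/C=C/c2cc(=O)cco2)cc1` and compound 2 `COc1ccc(/C=C/c2cc(=O)cco2)cc1OC` share one core; compound 3 `COc1cc(/C=C/C2CC=CC(=O)O2)cc(OC)c1` carries a different core, and the difference between the two cores is not broken down here. In a functional assay on U-251 cells (Homo sapiens) for inhibition, read by sulforhodamine B assay, with a stated time of 48 h (a lower number here means a stronger inhibitor of growth, a higher number a weaker inhibitor of growth), compound 1 gives 278 uM, and compound 2 gives 339 uM. The step of a 1.2-fold higher number from compound 1 to compound 2 (0.09 log units; within the scatter) corresponds to the change (methoxy in place of hydrogen on an aromatic carbon). Compound 3 stands apart: in this assay compound 3 gives 8.1 uM, the lowest number of the three measured compounds, and its steps to compound 1 and compound 2 are both beyond the scatter.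

Compound 4 `COc1cc(/C=C/C2CC=CC(=O)O2)cc(OC)c1OC` has not been measured in this assay. It differs from compound 3 by the change (methoxy in place of hydrogen on an aromatic carbon). This is the same kind of change as from compound 1 to compound 2, but not the same: in compound 2 the entering methoxy sits ortho to a methoxy group and meta to a group of 9 heavy atoms, whereas in compound 4 it sits ortho to two methoxy groups and para to a group of 9 heavy atoms. Going by the values given here, the only measured precedent for this kind of change is the step from compound 1 to compound 2, which lies within the scatter. On that basis the expected step of a 1.2-fold higher number from compound 3 to compound 4 (0.09 log units; within the scatter) is small. Among the compounds with values here, compound 4 is therefore estimated at 10 uM in this assay, with a likely range from 4 uM to 30 uM, because compound 3 gives 8.1 uM and the one comparable change left the number essentially unchanged.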

Compound 4, concentration for growth inhibition (reported as GI): 25.1 uM
For compound 4 the middle estimate is 2.5-fold (0.40 log units) below the measured one; low and high end bracket the measured number.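

On the core of compound 3, methoxy in place of hydrogen on an aromatic carbon, ortho to two methoxy groups and para to a group of 9 heavy atoms, gives a 3.1-fold higher number from compound 3 to compound 4 (0.49 log units; beyond the scatter) in this assay. Set beside the step on the core of compound 1, the result gives no sign that the size of this change differs between the two cores: the same change on two cores in this assay, a 1.2-fold higher number (0.09 log units; within the scatter) from compound 1 to compound 2 and a 3.1-fold higher number (0.49 log units; beyond the scatter) from compound 3 to compound 4, 2.5-fold (0.41 log units) apart, within the scatter of two such steps This does not show that the change carries over unaltered, as the series offers only two such pairs, one step lies within the scatter and the other beyond it, and the entering methoxy sits in a different place in each pair, so core and position cannot be told apart.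

The compounds shown carry only methoxy groups on the aromatic ring, which leaves open how a hydroxyl, an amine, a carboxylic acid or a longer alkoxy chain at the same place would read in this assay. What each core contributes by itself also stays open, as no pair shown differs in the core alone.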